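The source may hold more compounds than are shown below. What is called first, only, known or untested is meant among the compounds shown, and "the series" means these compounds.

Measured so far:
Compound 1, `O=C1NCCc2nc(C#Cc3ccccc3)sc21`: 112 nM
Compound 2, `O=C1NCCc2nc(C#Cc3cccc(F)c3)sc21`: 290 nM

Compound 2 stands at the higher of the two numbers in an assay on HEK293 cells for positive allosteric modulation of metabotropic glutamate receptor 5 (Homo sapiens), read by FLIPR, with a stated time of 1 h; a higher number here means that more compound is needed for the effect, a lower number that less compound is needed; its nearest neighbour is compound 1, at 112 nM, and the change from compound 1 to compound 2, fluoro in place of hydrogen on an aromatic carbon, gave a 2.6-fold higher number from compound 1 to compound 2 (0.41 log units; beyond the scatter).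

Compound 3, `Cc1cccc(C#Cc2nc3c(s2)C(=O)NCC3)c1`, is not yet measured. It differs from compound 2 by methyl in place of fluoro on an aromatic carbon, on an aromatic carbon of a six-membered aromatic ring of carbon only, meta to a large group. Among the compounds with values here, no measured step exchanges methyl for fluoro here; the only step that bears on this position is the one from hydrogen to fluoro, a 2.6-fold higher number from compound 1 to compound 2 (0.41 log units; beyond the scatter), a modest shift. A substituent of one heavy atom at this place is thus expected to leave the number near that of compound 2, with no step beyond the scatter expected, a 1.2-fold lower number from compound 2 to compound 3 (0.06 log units; within the scatter). For compound 3 the estimate in this assay is 250 nM, range 100 nM to 700 nM.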

Compound 3, half-maximal effective concentration: > 10000 nM
Compound 3 was reported as a limit (the forecaster's own chance of this, stated with the estimate: 3%); at least 40-fold (1.60 log units) between middle value and limit.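

In this assay compound 3 is reported only as a limit, > 10000 nM. The position on this aromatic carbon, meta to a large group, is therefore far from indifferent to a substituent of one heavy atom: methyl in place of fluoro gives an at least 34-fold higher number from compound 2 to compound 3 (1.53 log units; beyond the scatter), and methyl in place of hydrogen gives an at least 89-fold higher number from compound 1 to compound 3 (1.95 log units; beyond the scatter), both large beside the modest 2.6-fold higher number from compound 1 to compound 2 (0.41 log units; beyond the scatter). Hydrogen and fluoro thus give measurable numbers where methyl does not, and the true size of both new steps stays unknown: the limit of > 10000 nM in this assay, at which 1 of the 3 values shown sits.

With only hydrogen, fluoro and methyl at this place, the compounds shown do not explain the result for compound 3. From the compounds shown here alone, whether a chloro, a methoxy or a nitrile here would behave like fluoro or like methyl remains open.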